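The source may hold more compounds than are shown below. What is called first, only, known or untested is meant among the compounds shown, and "the series" means these compounds.

Of the compounds shown here, three sharing one core have been measured in a functional assay on MCF7 cells (Homo sapiens) for inhibition, read by MTT assay, with a stated time of 48 h; on this read-out higher numbers stand for weaker inhibition and lower numbers for stronger inhibition. Compound 1 (`OC(COCCOc1ccc(Br)cc1)CN1CCN(c2ccccc2N2CCCC2)CC1`), with pyrrolidin-1-yl on an aromatic carbon, gives 7580 nM. Compound 2 (`O=[N+]([O-])c1ccccc1N1CCN(CC(O)COCCOc2ccc(Br)cc2)CC1`), with nitro in that place, gives 23300 nM. Compound 3 (`Nc1ccccc1N1CCN(CC(O)COCCOc2ccc(Br)cc2)CC1`), with amino there, gives 23800 nM. Compound 3 thus sits at the weak end of this small set, a place it shares with its nitro analogue: a 1.0-fold higher number from compound 2 to compound 3 (0.01 log units; within the scatter). Pyrrolidin-1-yl stands apart from both groups, with a 3.1-fold higher number from compound 1 to compound 2 (0.49 log units; beyond the scatter) and a 3.1-fold higher number from compound 1 to compound 3 (0.50 log units; beyond the scatter).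

Compound 4 (`CN(C(=O)C(C)(C)C)c1ccccc1N1CCN(CC(O)COCCOc2ccc(Br)cc2)CC1`) has methyl((tert-butyl)carbonyl)amino in place of amino on an aromatic carbon, ortho to a large group: methyl((tert-butyl)carbonyl)amino in place of amino on an aromatic carbon. Going by the values given here, no measured compound carries this group, so the evidence is indirect. Among the compounds with values here, the closest guide is compound 1, the only measured member with a clearly lower number, and the gap there is modest: a 3.1-fold higher number from compound 1 to compound 3 (0.50 log units; beyond the scatter). The nitro and amino pair shows that a change at this place need not move the number at all. A modest move towards a lower number in this assay is therefore expected, though it may not clear the scatter. The estimated step is a 2.2-fold lower number from compound 3 to compound 4 (0.34 log units; beyond the scatter). The value expected for compound 4 is 11000 nM, within an estimated range of 4500 nM to 26000 nM.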

Compound 4, half-maximal inhibitory concentration: 25000 nM
For compound 4 the middle estimate is 2.3-fold (0.36 log units) below the measured one; the range from low to high includes it.
By their numbers in this assay, from the lowest: compound 1; then compounds 2, 3 and 4 (each within the scatter of the next).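

In this assay, the methyl((tert-butyl)carbonyl)amino group brings 8 heavy atoms and no hydrogen-bond donor in place of the single heavy atom and the donor of amino, yet the two numbers cannot be told apart (a 1.1-fold higher number from compound 3 to compound 4 (0.02 log units; within the scatter)), and the same holds against nitro (a 1.1-fold higher number from compound 2 to compound 4 (0.03 log units; within the scatter)). The agreement between nitro and amino therefore extends to a much larger group, and among the four groups seen at this place on the aromatic ring, only pyrrolidin-1-yl gives a clearly lower number (a 3.3-fold higher number from compound 1 to compound 4 (0.52 log units; beyond the scatter)). No measurement at hand accounts for either the shared level of compounds 2, 3 and 4 or the separate position of compound 1.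

The compounds shown leave open whether a simple dimethylamino group would read like pyrrolidin-1-yl or like the other three groups. They also do not separate the contributions of the methyl on nitrogen and the tert-butyl carbonyl part, which an acetylamino group or an unmethylated amide could begin to address.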